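Extending a Side Chain: Expected Effect on Aromatase Inhibition

A few compounds are considered here, and "the series" means these few. Any claim that something is new, unique, unknown or untested is made for them only; others in the source may bear on it.

Compound 1 `c1ccc(C(c2ccccc2)n2ccnn2)cc1` and compound 2 `CCCc1cn(C(c2ccccc2)c2ccccc2)nn1` share a common core and were both tested in an assay on isolated protein for inhibition of Aromatase (Homo sapiens), read by fluorescence and colorimetric assay, with a stated time of 30 min; a higher number here means a weaker inhibitor, a lower number a stronger inhibitor. Compound 1 gives 4580 nM, while compound 2 gives 11000 nM, the higher of the two numbers. Among the compounds with values here, the only measured step, a 2.4-fold higher number from compound 1 to compound 2 (0.38 log units; beyond the scatter), came from adding a propyl group. Compound 3 `CCCCCCc1cn(C(c2ccccc2)c2ccccc2)nn1` carries propyl in place of hydrogen on a saturated chain carbon, three bonds along the chain from an aromatic carbon. Because a 2.4-fold higher number from compound 1 to compound 2 (0.38 log units; beyond the scatter) already weakened inhibition modestly, lengthening the same chain further is expected to weaken it again by a comparable modest amount, giving a 1.6-fold higher number from compound 2 to compound 3 (0.21 log units; within the scatter). Compound 3 is therefore expected to give about 18000 nM, within the range 7000 nM to 45000 nM.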

Compound 3, half-maximal inhibitory concentration: 14800 nM
For compound 3 the middle estimate is 1.2-fold (0.09 log units) above the measured one, within the range that was stated.
By their numbers in this assay, from the lowest: compound 1; then compounds 2 and 3 (each within the scatter of the next).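

Lengthening propyl to hexyl gives a 1.3-fold higher number from compound 2 to compound 3 (0.13 log units; within the scatter), so in this assay the added carbons on the saturated chain show no change that can be told from the scatter. Against the hydrogen of compound 1, hexyl still gives a 3.2-fold higher number from compound 1 to compound 3 (0.51 log units; beyond the scatter), so the full chain leaves a modest weakening, much like that seen with propyl. Nothing shown here explains either step.

From the compounds shown here alone, it remains open whether a chain longer than hexyl would stay within the scatter of compound 3. A chain carrying an amine or a carboxylic acid could also behave differently.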